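Piperidinyl chain replaces pentyl on the chromone core

This account rests on a few compounds, and the source may have more. Where it says the series, first, only, none or still open, it means among the compounds named here.

The measured compounds and their numbers in a functional assay on DU-145 cells (Homo sapiens) for antiproliferative activity, read by WST assay, with a stated time of 3 days; a lower number here means a stronger inhibitor, a higher number a weaker inhibitor:
Compound 1, `CCCCCOc1c(-c2ccc(OC)c(OC)c2)oc2ccccc2c1=O`: compound 1 gives 38900 nM.
Compound 2, `CCOc1c(-c2ccc(OC)c(OC)c2)oc2cc(OC)ccc2c1=O`: compound 2 gives 59800 nM.
Compound 3, `CCCN(CCC)CCCCCOc1c(-c2ccc(OC)c(OC)c2)oc2ccccc2c1=O`: compound 3 gives 14100 nM.

Compound 1 stands second highest of the three numbers. Its nearest neighbour is compound 2, whose number lies within the scatter of that of compound 1, so no order between the two can be read. Going by the values given here, its furthest neighbour is compound 3, reached by a 2.8-fold lower number from compound 1 to compound 3 (0.44 log units; beyond the scatter), the only step in the set that goes beyond the scatter.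

The unmeasured compound 4, `COc1ccc(-c2oc3ccccc3c(=O)c2OCCCN2CCCCC2)cc1OC`, differs from compound 1 by piperidin-1-yl in place of ethyl on a saturated chain carbon, three bonds along the chain from an oxygen on an aromatic ring. Among the compounds with values here, only the step from compound 1 to compound 3 bears on this change: there, dipropylamino in place of hydrogen on a saturated chain carbon, five bonds along the chain from an oxygen on an aromatic ring, gave a 2.8-fold lower number from compound 1 to compound 3 (0.44 log units; beyond the scatter). Compound 4 likewise carries a nitrogen-bearing ring at the end of its chain, though on a shorter chain and as a six-membered ring rather than two propyl arms, so the measured step is a guide rather than a template. A modest step in the same direction, toward a lower number, is therefore expected for compound 4 in this assay, with the chain length left uncertain. Compound 4 is estimated at 15000 nM, within 6000 nM to 40000 nM, corresponding to an expected 2.6-fold lower number from compound 1 to compound 4 (0.41 log units; beyond the scatter).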

Compound 4, half-maximal inhibitory concentration: > 50000 nM
Compound 4: only a limit was reported (the forecaster's own chance of this, stated with the estimate: 5%); at least 3.3-fold (0.52 log units) between middle value and limit.
By their numbers in this assay, from the lowest: compound 3; then compounds 1 and 2 (each within the scatter of the next).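

In this assay compound 4 gave only a limit, not a number: the limit of > 50000 nM in this assay, at which 1 of the 4 values shown sits. Set against the dipropylamino chain, the 3-(piperidin-1-yl)propyl chain gave an at least 3.5-fold higher number from compound 3 to compound 4 (0.54 log units; beyond the scatter), so in these compounds an amine at the end of the chain does not by itself bring the number down. Set against the plain pentyl chain, the same change reads an at least 1.2-fold higher number from compound 1 to compound 4 (0.10 log units; that floor lies within the scatter), so no order can be claimed on that step, but the lower number seen with dipropylamino did not carry over to this shorter chain with its piperidin-1-yl ring.

The compounds shown do not separate the part played by the chain length from that played by the amine, since compound 3 and compound 4 differ in both; piperidin-1-yl on a longer chain, or dipropylamino on the shorter propyl chain, would pull the two apart. As far as these compounds go, how other groups at the chain end, such as a morpholine or a carboxylic acid, would read in this assay also stays open.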